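The source may report more compounds than this note shows. Statements on the series, on what has been measured and on what is new or still open speak of the compounds shown alone.

Measured compounds so far:
- compound 1 `O=C1C(NC2CCCC2)=CC(=O)c2c1nc1n2[C@H]2OC[C@@H](O)[C@H]2OC1`, > 16000 nM
- compound 2 `CCOc1ccc(NC2=CC(=O)c3nc4n(c3C2=O)[C@H]2OC[C@@H](O)[C@H]2OC4)cc1`, 1110 nM
- compound 3 `COc1ccc(NC2=CC(=O)c3nc4n(c3C2=O)[C@H]2OC[C@@H](O)[C@H]2OC4)cc1`, 1680 nM

In a functional assay on MGC-803 cells (Homo sapiens) for inhibition, read by sulforhodamine B assay (on this read-out lower numbers stand for stronger inhibition and higher numbers for weaker inhibition), compound 1 gives only a limit, > 16000 nM, and no number; it sits at the limit of > 16000 nM in this assay, at which 1 of the 3 values shown sits. Compound 2 gives 1110 nM in this assay. Compound 3 gives 1680 nM. For the measured compounds named here, the one measured step, a 1.5-fold higher number from compound 2 to compound 3 (0.18 log units; within the scatter), does not separate the two and says nothing about the amine substituent itself.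

The step now followed, from compound 1 to compound 4 `CCOc1ccc(NC2=CC(=O)c3c(nc4n3[C@H]3OC[C@@H](O)[C@H]3OC4)C2=O)cc1`, is 4-ethoxyphenyl in place of cyclopentyl on an amine nitrogen. Going by the values given here, no measured step covers this exchange. The only bearing is indirect: compound 2 carries the same 4-ethoxyphenyl on its amine nitrogen, on a differently arranged core, and gives a number rather than a limit. Compound 4 is therefore expected to fall into the measurable range, a step of an at least 10-fold lower number from compound 1 to compound 4 (1.02 log units; beyond the scatter) in the direction of stronger inhibition, with wide uncertainty since the core arrangement differs from compound 2. The estimate for compound 4 is 1500 nM, expected between 500 nM and 6000 nM.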

Compound 4, half-maximal inhibitory concentration: 2090 nM
Compound 4: middle estimate off by 1.4-fold (0.14 log units), on the low side; the range from low to high includes it.
By their numbers in this assay, from the lowest: compounds 2, 3 and 4 (each within the scatter of the next). At a limit, above all of these: compound 1.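

On the amine nitrogen of the core of compound 1, 4-ethoxyphenyl in place of cyclopentyl gives, in this assay, an at least 7.6-fold lower number from compound 1 to compound 4 (0.88 log units; beyond the scatter), the direction of stronger inhibition. For the compounds shown here, the earlier measured step touched only the alkoxy chain on the aromatic ring, so this is the first step that bears on the amine substituent itself, and it shows that the substituent at this place can move a compound from a limit into the measurable range. The reading for compound 1 is a limit and not a number, so the true size of the step stays open on one side: the limit of > 16000 nM in this assay, at which 1 of the 4 values shown sits.

The compounds shown cannot tell whether the aromatic ring or the ethoxy chain accounts for the change. Plain phenyl, 4-hydroxyphenyl or an open-chain butyl on the same amine nitrogen would separate these.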